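A few compounds are considered here, and "the series" means these few. Any claim that something is new, unique, unknown or untested is made for them only; others in the source may bear on it.

Measured so far in an assay on isolated protein for inhibition of Ectonucleotide pyrophosphatase/phosphodiesterase family member 1 (Homo sapiens), tested at 10 uM; on this read-out higher numbers stand for more inhibition at the one concentration tested (going by the name of the read-out) and lower numbers for less inhibition:
- compound 1 `O=C(CSc1nc2cccnc2[nH]1)Nc1ccccc1`: 30%
- compound 2 `O=C(CSc1nc2cccnc2[nH]1)Nc1ccc(Cl)cc1`: 17%
- compound 3 `O=C(CSc1nc2cccnc2[nH]1)Nc1ccccc1F`: 13%

Compound 1 stands highest of the three numbers in this assay. Its nearest neighbour is compound 2, reached by a number 13 percentage points lower from compound 1 to compound 2 (beyond the scatter); the furthest is compound 3, reached by a number 17 percentage points lower from compound 1 to compound 3 (beyond the scatter). Between compound 2 and compound 3 the change is a number 4 percentage points lower from compound 2 to compound 3 (within the scatter), so the two substituted compounds cannot be told apart.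

Compound 4 `CCOC(=O)c1cccc(NC(=O)CSc2nc3cccnc3[nH]2)c1` is the next member to be measured in this assay. It differs from compound 1 by ethoxycarbonyl in place of hydrogen on an aromatic carbon.

For the measured compounds named here, the steps that bear on this change are those from compound 1 to compound 2 and from compound 1 to compound 3: in both, a group entering on the phenyl ring of the anilide lowered the number beyond the scatter, by a modest amount. Neither step tested an ethoxycarbonyl group nor this place on the ring, so the expectation for compound 4 rests on the direction shared by those two steps and carries a wide range. A modest lowering, or at most a change at the edge of the scatter, is expected. The step from compound 1 to compound 4 is estimated as a number 12 percentage points lower from compound 1 to compound 4 (beyond the scatter). Compound 4 is therefore estimated at 18%, with a range from 5% to 35%.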

Compound 4, a percentage reported as inhibition, at one concentration (the size of the read-out at that concentration, not a potency): 15%
Compound 4: middle estimate off by 3 percentage points, on the high side, and the stated range covers the measured number.
By their numbers in this assay, from the lowest: compounds 3, 4 and 2 (each within the scatter of the next); then compound 1.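

In this assay, ethoxycarbonyl on an aromatic carbon meta to a large group gives a number 15 percentage points lower from compound 1 to compound 4 (beyond the scatter) on the anilide phenyl ring, at a place not occupied in compound 2 or compound 3. The direction therefore extends beyond the two halogens: with a number 13 percentage points lower from compound 1 to compound 2 (beyond the scatter) and a number 17 percentage points lower from compound 1 to compound 3 (beyond the scatter) alongside it, all three substituted compounds shown lie beyond the scatter below the unsubstituted compound 1, none goes against this, and the entering group can be as large as 5 heavy atoms with 2 hydrogen-bond acceptors and no ring. No measurement on hand bears on what lies behind this lowering.

Whether the lowering belongs to ethoxycarbonyl itself or to any group at this place stays open, since this place has only the one substituent among the compounds shown. A carboxylic acid, a methoxy group or an amine at the same aromatic carbon, each compared directly with compound 1, would help separate these two readings, and a longer chain on the oxygen of the ethoxycarbonyl group would test how far the group can grow.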